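One Methoxy Fewer at the Assay Limit

This account rests on a few compounds, and the source may have more. Where it says the series, first, only, none or still open, it means among the compounds named here.

In a functional assay on SW982 cells (Homo sapiens) for inhibition, read by MTT assay, with a stated time of 72 h (on this read-out lower numbers stand for stronger inhibition and higher numbers for weaker inhibition), compound 1 (`COc1cc(OC)c(OC)cc1/C=C/C(=O)c1cc(Cl)ccc1O`) gives > 150000 nM as its reading, which is a limit and not a number. Compound 2 (`COc1cc(C(=O)/C=C/c2cc(OC)c(OC)cc2OC)ccc1O`) reads > 150000 nM and this too is a limit and not a number. Compound 2 thus stands at the limit of > 150000 nM in this assay, at which 2 of the 2 values shown sit, and has no number of its own.

Compound 3 (`COc1cc(OC)c(OC)cc1/C=C/C(=O)c1ccc(O)cc1`) is reached from compound 2 by a single change (hydrogen in place of methoxy on an aromatic carbon) with hydrogen in place of methoxy on an aromatic carbon, ortho to a hydroxy group. Going by the values given here, no measured step between related compounds is available to size this change. In this assay no shift beyond the scatter is therefore the main expectation, and any shift that does appear would most likely be small and toward stronger inhibition. The expected size of the change is an at least 1.0-fold lower number from compound 2 to compound 3 (0.02 log units; that floor lies within the scatter) as estimated here. For compound 3 the estimate is 140000 nM with an expected range from 50000 nM to 300000 nM and the reading may well turn out to be a limit again.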

Compound 3, half-maximal inhibitory concentration: 155000 nM
The estimate for compound 3 lay 1.1-fold (0.04 log units) below the measured number; measured number inside the range.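

In this assay neither step to compound 3 can be read, whether from compound 2 or from compound 1, since each of those two compounds has only a limit and no number of its own: the limit of > 150000 nM in this assay, at which 2 of the 3 values shown sit. What the compounds shown leave open is how large either change is, and in which direction it moves the reading.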